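Bromo for fluoro in a compound at the assay limit

The compounds below may be only part of what the source reports. "The series", "measured", "known", "first", "only" and "open" are said of these compounds alone.

In a physicochemical assay for solubility, read by HPLC, at pH 7.4 (a lower number here means a less soluble compound, a higher number a more soluble compound), compound 1 (`COc1ccc2c(c1)c(=O)c(Cc1ccccc1)c(C)n2C`) gives 10000 nM. Compound 2 (`CCc1c(C)[nH]c2cc(OC)c(F)cc2c1=O`) reads < 2000 nM, and this reading is a limit of the assay, not a number. Compound 2 therefore has no exact position in the series, only a bound. Among the measured compounds shown here, compound 1 and compound 2 differ in more than one place, so no measured step exists for sizing the next change.

Compound 3 (`CCc1c(C)[nH]c2cc(OC)c(Br)cc2c1=O`) keeps the shared core of compound 2 and has bromo in place of fluoro on an aromatic carbon, ortho to a methoxy group: bromo in place of fluoro on an aromatic carbon.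

For the measured compounds named here, with no measured precedent for this exchange, the working expectation in this assay is no step beyond the scatter, and no direction is favoured. Going by the values given here, the expectation rests on compound 2 at < 2000 nM, the only close neighbour of compound 3, and a second limit reading is the likely outcome. The estimated change is a step that the limit leaves unreadable from compound 2 to compound 3. If a number is returned, the estimate for compound 3 is 1000 nM, with an expected range of 300 nM to 2000 nM.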

Compound 3, solubility: 2000 nM
Estimate against measurement, compound 3: 2.0-fold (0.30 log units) below; the measured number falls inside the stated range.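

In this assay, bromo in place of fluoro on this aromatic carbon, ortho to a methoxy group, gives a number no lower from compound 2 to compound 3 (the limit leaves the size open). The reading for compound 2, < 2000 nM, is a limit of the assay and not a number. Among the compounds shown here, compound 3 gives 2000 nM, which is the first actual number on the shared core of this pair and a fixed point that compound 2 could not provide. The exchange itself still has no readable size, because one end of the step is a limit: the limit of < 2000 nM in this assay, at which 1 of the 3 values shown sits.

With only fluoro and bromo shown on this aromatic carbon, the reading in this assay for chloro, an amine or a carboxylic acid at the same place remains open. Also open, as far as these compounds go, is whether a longer chain in place of the ethyl group would shift the reading of compound 3, whose number, unlike the limit of its fluoro neighbour, would allow such a step to be sized.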